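The source may report more compounds than this note shows. Statements on the series, on what has been measured and on what is new or still open speak of the compounds shown alone.

Measured compounds:
compound 1, `Cc1nc(S(C)(=O)=O)ccc1Oc1ncnc(OC2CCN(C(=O)SC3CCC3)CC2)c1F`, which in a functional assay on isolated protein for inhibition of Glucose-dependent insulinotropic receptor (Rattus norvegicus), read by HTRF and cAMP accumulation (on this read-out lower numbers stand for an effect already at smaller amounts and higher numbers for an effect only at larger amounts of compound), gives 77.4 nM;
compound 2, `Cc1nc(S(C)(=O)=O)ccc1Oc1ncnc(OC2CCN(C(=O)C3(F)CCC3)CC2)c1F`, which in this assay gives 123 nM.

Compound 2 cannot be separated from compound 1 on these numbers, since the step of a 1.6-fold higher number from compound 1 to compound 2 (0.20 log units; within the scatter) lies within the scatter of repeated measurements. Compound 3, `Cc1nc(S(C)(=O)=O)ccc1Oc1ncnc(OC2CCN(C(=O)c3noc(C(C)C)n3)CC2)c1F`, is not yet measured; it differs from compound 2 in a group of 8 heavy atoms (5 carbon, 2 nitrogen, 1 oxygen; one five-membered aromatic ring with 3 hetero atoms) in place of a group of 5 heavy atoms (4 carbon, 1 fluorine; one four-membered non-aromatic ring of carbon only), on a carbonyl carbon. Among the compounds with values here, only one measured step touches the same carbonyl carbon, the exchange from compound 1 to compound 2, and that step was small. The group now entering is larger and of a different kind, so this single step is a weak guide, and no step beyond the scatter is expected in either direction, with wide uncertainty. Compound 3 is therefore estimated at 130 nM, within the range 40 nM to 420 nM, an expected step of a 1.1-fold higher number from compound 2 to compound 3 (0.02 log units; within the scatter).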

Compound 3, half-maximal effective concentration: 176 nM
Beside the measured number, compound 3's estimate is 1.4-fold (0.13 log units) below it; the measured number falls inside the stated range.
By their numbers in this assay, from the lowest: compounds 1, 2 and 3 (each within the scatter of the next, the first and the last beyond it).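

The carbonyl carbon now carries an aromatic ring, 5-isopropyl-1,2,4-oxadiazol-3-yl, which has more heavy atoms than either earlier group, yet in this assay the exchange for the four-membered carbon ring with its fluorine gives a 1.4-fold higher number from compound 2 to compound 3 (0.16 log units; within the scatter), so these two groups cannot be told apart on this read-out. Set against cyclobutylsulfanyl, the same ring gives a 2.3-fold higher number from compound 1 to compound 3 (0.36 log units; beyond the scatter), the first step at this position to clear the scatter, though only a modest one. Nothing measured here bears on why the numbers fall as they do.

Still open, from the compounds shown here alone, is what a longer chain in place of the isopropyl on the ring would do to the number. Equally open, going by these compounds, is how an amine or a carboxylic acid-bearing group would read on the same carbonyl carbon.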